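The compounds below may be only part of what the source reports. "The series", "measured", "known", "first", "only" and "open" are said of these compounds alone.

Compound 2 `C#CCNC(=O)/C(C)=C(\C)c1ccc(C)cc1` gives the lowest of the two numbers seen so far: in a toxicity assay on the whole organism (strain Icem-CET (SPF Caw)) for cytotoxicity, with Mus musculus as the target (a higher number here means that more compound is needed for the effect, a lower number that less compound is needed), compound 2 gives 200 mg/kg. Compound 1 `C/C(C(=O)NC1CC1)=C(/C)c1ccc(Br)cc1` differs from compound 2 in two places. In this assay compound 1 gives 600 mg/kg, a number beyond the scatter above that of compound 2. Compound 3 `C/C(C(=O)NC1CC1)=C(/C)c1ccc(C)cc1` carries cyclopropyl in place of propargyl on an amide-type nitrogen. Within the data shown here, no measured pair shows this change alone; compound 1 carries the cyclopropyl and gives the higher number, but also differs elsewhere. A modest rise is therefore expected, a 1.8-fold higher number from compound 2 to compound 3 (0.24 log units; within the scatter). For compound 3 in this assay the estimate is 350 mg/kg, within 150 mg/kg to 800 mg/kg.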

Compound 3, dose for half-maximal effect: 300 mg/kg
The estimate for compound 3 lay 1.2-fold (0.07 log units) above the measured number; the range from low to high includes it.
By their numbers in this assay, from the lowest: compounds 2, 3 and 1 (each within the scatter of the next, the first and the last beyond it).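

In this assay, cyclopropyl in place of propargyl on an amide-type nitrogen, now seen alone, gives a 1.5-fold higher number from compound 2 to compound 3 (0.18 log units; within the scatter) and so does not separate the two groups at this position. Methyl in place of bromo on an aromatic carbon, also seen alone, gives a 2.0-fold lower number from compound 1 to compound 3 (0.30 log units; within the scatter) and likewise sits at the edge of what repeat measurements would show. No supporting data bear on either step.

From the compounds shown here alone, each change rests on a single pair, so its size on other compounds remains open. Going by these compounds, whether an amine on the aromatic carbon or a longer chain on the amide-type nitrogen would shift the number beyond the scatter also remains open.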